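Notes on 4-chlorophenyl replacing 3,4-dimethoxyphenyl

This account rests on a few compounds, and the source may have more. Where it says the series, first, only, none or still open, it means among the compounds named here.

Compound 1 `COc1ccc(-c2c(-c3cc(OC)c(OC)c(OC)c3)noc2N(C(C)=O)C(C)=O)cc1`: 1360 nM
Compound 2 `COc1ccc(-c2c(-c3cc(OC)c(OC)c(OC)c3)noc2N(C(C)=O)C(C)=O)cc1OC`: > 50000 nM

In a functional assay on SMMC-7721 cells (Homo sapiens) for cytotoxicity, read by MTT assay, with a stated time of 48 h (a lower number here means a stronger inhibitor, a higher number a weaker inhibitor), compound 2 stands at > 50000 nM, which is a limit and not a number.

Compound 3 `COc1cc(-c2noc(N(C(C)=O)C(C)=O)c2-c2ccc(Cl)cc2)cc(OC)c1OC` is not yet measured. It carries 4-chlorophenyl in place of 3,4-dimethoxyphenyl on an aromatic carbon. Among the measured compounds shown here, the one measured step that bears on this is an at least 36-fold higher number from compound 1 to compound 2 (1.56 log units; beyond the scatter), a large one. Compound 3 lacks the methoxy added in that step, as does compound 1 at 1360 nM, so a large step towards a lower number is expected. For the measured compounds named here, this rests on a single step, and no measured compound here carries 4-chlorophenyl. The expected change is an at least 16-fold lower number from compound 2 to compound 3 (1.22 log units; beyond the scatter). In this assay the estimated value for compound 3 is 3000 nM, with an expected range of 500 nM to 20000 nM.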

Compound 3, half-maximal inhibitory concentration: > 50000 nM
Compound 3 ended at the assay's limit; the forecaster's own chance of this, stated with the estimate: 10%; at least 16-fold (1.22 log units) between middle value and limit.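

In this assay, chloro in place of methoxy on an aromatic carbon gives an at least 36-fold higher number from compound 1 to compound 3 (1.56 log units; beyond the scatter). At this position, then, the value worsens not only when a methoxy is added, as in compound 2, but also when the methoxy of compound 1 is exchanged for chloro. Compound 2 and compound 3 both stand at a limit and not at a number, so the step between them cannot be read, and compound 1 alone keeps a readable value: the limit of > 50000 nM in this assay, at which 2 of the 3 values shown sit.

As far as these compounds go, whether any other group at this place can match compound 1 stays open; a hydroxy, an amine or a methyl in place of the methoxy would test this. From the compounds shown here alone, how far compound 2 and compound 3 lie beyond the limit also stays open.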